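Swapping Methoxy for Hydroxy on a Shared Core

A few compounds are considered here, and "the series" means these few. Any claim that something is new, unique, unknown or untested is made for them only; others in the source may bear on it.

In a functional assay on NCI-H460 cells (Homo sapiens) for cytotoxicity, read by MTT assay, with a stated time of 48 h (a lower number here means a stronger inhibitor, a higher number a weaker inhibitor), compound 1 `COc1cc(/C=C/C(=O)/C=C/c2nc3c(C)c(C)ccc3n2C)ccc1O` gives 31900 nM and compound 2 `COc1ccc2c(c1)nc(/C=C/C(=O)/C=C/c1ccc(O)c(OC)c1)n2C` gives 12700 nM as the lower of the two numbers, which makes compound 2 the stronger inhibitor of this pair. Compound 3 `COc1cc(/C=C/C(=O)/C=C/c2nc3cc(O)ccc3n2C)ccc1O` differs from compound 2 by hydrogen in place of methyl on an oxygen on an aromatic ring, counted as hydrogen in place of methyl on an oxygen on an aromatic ring and also read as methoxy to hydroxy. For the measured compounds named here, no measured pair shows this change, so in this assay only a small move toward a weaker number is expected: the estimated 1.3-fold higher number from compound 2 to compound 3 (0.10 log units; within the scatter) should stay within the usual scatter. In this assay compound 3 is expected at 16000 nM with an estimated range from 6000 nM to 40000 nM as a rough guide.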

Compound 3, half-maximal inhibitory concentration: 7600 nM
Compound 3: middle estimate off by 2.1-fold (0.32 log units), on the high side; low and high end bracket the measured number.
By their numbers in this assay, from the lowest: compounds 3 and 2 (each within the scatter of the next); then compound 1.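

In this assay, for the compounds shown here, the first direct look at this oxygen on the aromatic ring shows that exchanging methoxy for hydroxy gives a 1.7-fold lower number from compound 2 to compound 3 (0.22 log units; within the scatter). The methyl can therefore be removed here, leaving a free hydroxy, without a change that stands clear of the usual scatter of repeated measurements. Nothing available points to a cause for this result. The compounds shown leave open what other groups on this oxygen would do, such as a longer chain. They also leave open whether an amine in place of the hydroxy would move the number beyond the scatter.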